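The source may report more compounds than this note shows. Statements on the series, on what has been measured and on what is new or still open speak of the compounds shown alone.

Measured so far:
compound 1, `COc1ccccc1C(=O)NC(=O)Nc1ccc(N2CCCCC2)c(Cl)c1`: 3.6 ug/mL
compound 2, `COc1ccccc1C(=O)NC(=O)Nc1ccc(-c2ccccn2)c(C(F)(F)F)c1`: 28 ug/mL
compound 3, `COc1ccccc1C(=O)NC(=S)Nc1ccc(N2CCCCC2)c(Cl)c1`: < 1 ug/mL

In a physicochemical assay for solubility (on this read-out lower numbers stand for lower solubility and higher numbers for higher solubility), compound 2 holds the highest of the two numbers recorded; compound 1 sits well beneath it in this assay, a gap that lies beyond the usual scatter. For compound 3 this assay reports only a limit and no number: the limit of < 1 ug/mL in this assay, at which 1 of the 3 values shown sits. Compound 4, `COc1ccccc1C(=O)NC(=O)Nc1ccc(-c2nccs2)c(C(F)(F)F)c1`, has not yet been measured in this assay. It differs from compound 2 in one place: 1,3-thiazol-2-yl in place of pyridin-2-yl on an aromatic carbon. Among the measured compounds shown here, no step of this kind exists among the measured compounds, so one expects only a small shift in this assay, downward, at the edge of the scatter. Compound 4 is therefore expected to give 20 ug/mL in this assay, with a range from 7 ug/mL to 50 ug/mL. That estimate corresponds to a 1.4-fold lower number from compound 2 to compound 4 (0.15 log units; within the scatter).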

Compound 4, solubility: 1.1 ug/mL
Compound 4: middle estimate off by 18-fold (1.26 log units), on the high side; measured number below the stated range.
By their numbers in this assay, from the lowest: compound 4; then compound 1; then compound 2. At a limit, below all of these: compound 3.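

In this assay, this aromatic carbon, ortho to a trifluoromethyl group, proves sensitive to the ring it carries, with a 25-fold lower number from compound 2 to compound 4 (1.41 log units; beyond the scatter) when 1,3-thiazol-2-yl takes the place of pyridin-2-yl. Among the compounds shown here, this is the first step at this place, and it lies well beyond the scatter. Compound 3 remains a limit and not a number, so it adds no step here: the limit of < 1 ug/mL in this assay, at which 1 of the 4 values shown sits.

The compounds shown leave open whether this fall belongs to 1,3-thiazol-2-yl alone or extends to other five-membered aromatic rings, such as oxazol-2-yl. From the compounds shown here alone, how a phenyl or pyrimidin-2-yl group would compare at this carbon also remains open.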